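This account rests on a few compounds, and the source may have more. Where it says the series, first, only, none or still open, it means among the compounds named here.

Measured compounds in a functional assay on the whole organism (strain albino) with Mus musculus as the target, at a dose of 100 mg/kg by the intraperitoneal route; on this read-out higher numbers stand for more inhibition at the one dose given (going by the name of the read-out) and lower numbers for less inhibition:
compound 1, `CCc1nc2ccccc2c(=O)n1NC(=O)Nc1ccc([N+](=O)[O-])cc1`: 41%
compound 2, `O=C(Nc1ccc([N+](=O)[O-])cc1)Nn1c(-c2ccccc2)nc2ccccc2c1=O`: 42%
compound 3, `Cc1cccc(NC(=O)Nn2c(-c3ccccc3)nc3ccccc3c2=O)c1`: 59%

Within the data shown here, compound 1 gives the lowest of the three numbers in this assay, though compound 2 sits within the scatter of it, as a number 1 percentage points higher from compound 1 to compound 2 (within the scatter) shows; only compound 3 lies clearly apart, and the step of a number 17 percentage points higher from compound 2 to compound 3 (beyond the scatter) is the one change here that goes beyond the scatter.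

Compound 4, `CCc1nc2ccccc2c(=O)n1NC(=O)Nc1ccc(F)cc1`, has not yet been measured in this assay. It differs from compound 1 in one place:
fluoro in place of nitro on an aromatic carbon

Among the measured compounds shown here, no measured step exchanges the nitro group on the aromatic carbon for a fluoro group, so there is no direct precedent. For the measured compounds named here, the closest bearing comes from compound 2 to compound 3, where removing the 4-nitrophenyl in favour of a 3-methylphenyl gave a number 17 percentage points higher from compound 2 to compound 3 (beyond the scatter); that change, however, alters more than the one group, and the step from compound 1 to compound 2 on a different part of the core stayed within the scatter. Compound 4 is therefore expected to come out modestly higher than compound 1, if at all, by about a number 8 percentage points higher from compound 1 to compound 4 (within the scatter), and its value in this assay is estimated at 49% with a range from 32% to 66%.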

Compound 4, a percentage reported as inhibition, in the whole organism at one dose (the size of the read-out at that dose, not a potency): 51%
The estimate for compound 4 lay 2 percentage points below the measured number; low and high end bracket the measured number.
By their numbers in this assay, from the lowest: compounds 1, 2, 4 and 3 (each within the scatter of the next, the first and the last beyond it).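

In this assay, the exchange of fluoro for nitro on an aromatic carbon, para to a large group, gives a number 10 percentage points higher from compound 1 to compound 4 (within the scatter), so this position takes a single fluorine atom in place of a three-atom nitro group, with its two hydrogen-bond acceptors, without a change that can be told from the scatter. The earlier step on this ring, from 4-nitrophenyl to 3-methylphenyl, replaced the substituent and its place on the ring together; with the ethyl compounds, the nitro group is now exchanged alone, with the rest of the molecule held constant. No measured property of either group bears on this result, and the data give no explanation for it.

The compounds shown leave open how an amine, a methoxy group or a chlorine atom on the same aromatic carbon would read, and whether a larger difference would appear with any of them. They also leave open whether fluoro in place of nitro gives a similar result when phenyl rather than ethyl sits on the core, as in compound 2.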